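Methyl on the Aromatic Ring: Two Related Cores Compared

The source may hold more compounds than are shown below. What is called first, only, known or untested is meant among the compounds shown, and "the series" means these compounds.

The study concerns four compounds that share a methyl ester and a methyl-bearing carbon skeleton, differing in how the aromatic part is joined to it. Compound 1 `COC(=O)[C@@]1(C)CCC=C2[C@@H]1CC[C@@H](C)[C@]2(C)Cc1c[nH]c2ccccc12` and compound 2 `COC(=O)[C@@]1(C)CCC=C2[C@@H]1CC[C@@H](C)[C@]2(C)Cc1c[nH]c2ccc(C)cc12` carry one core; compound 3 `COC(=O)[C@@]1(C)CC[C@@H]2C3=C1CC[C@@H](C)[C@]3(C)C[C@@H]1c3ccccc3N[C@H]21` and compound 4 `COC(=O)[C@@]1(C)CC[C@@H]2C3=C1CC[C@@H](C)[C@]3(C)C[C@@H]1c3cc(C)ccc3N[C@H]21` carry another. How the two cores differ is not broken down here; the two have the same atoms, joined differently.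

In a functional assay on HBL-100 cells (Homo sapiens) for inhibition, read by sulforhodamine B assay, with a stated time of 48 h (a lower number here means a stronger inhibitor of growth, a higher number a weaker inhibitor of growth), compound 1 gives 4500 nM. Compound 2 differs from compound 1 by methyl in place of hydrogen on an aromatic carbon. In the same assay compound 2 gives 18000 nM. The step of a 4.0-fold higher number from compound 1 to compound 2 (0.60 log units; beyond the scatter) shows that the methyl weakens growth inhibition on this core.

Compound 3 gives 78000 nM, the highest of the three measured numbers, standing beyond the scatter from both compound 2 and compound 1.

Compound 4 differs from compound 3 by methyl in place of hydrogen on an aromatic carbon. This is the same kind of change as from compound 1 to compound 2, but the place is not identical: the ring in compound 4 is part of a fused or bridged system of five rings rather than two. The expectation for compound 4 rests on the step of a 4.0-fold higher number from compound 1 to compound 2 (0.60 log units; beyond the scatter) seen for compound 1 and compound 2, and so compound 4 is expected to show a 3.2-fold higher number from compound 3 to compound 4 (0.51 log units; beyond the scatter). Compound 4 is therefore estimated at 250000 nM, within a range from 100000 nM to 600000 nM, with a real chance that only a limit is reported.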

Compound 4, concentration for 50% growth inhibition: 15000 nM
Beside the measured number, compound 4's estimate is 17-fold (1.22 log units) above it; the measured number lies below the stated range.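

On the core of compound 3, methyl in place of hydrogen on an aromatic carbon strengthens growth inhibition in this assay, with a 5.2-fold lower number from compound 3 to compound 4 (0.72 log units; beyond the scatter), so the change that weakened growth inhibition on the core of compound 1 acts the opposite way here. Set side by side, the two steps differ by more than the scatter of such steps allows, which shows that the outcome of this change in this series depends on the core that carries it: the same change on two cores in this assay, a 4.0-fold higher number (0.60 log units; beyond the scatter) from compound 1 to compound 2 and a 5.2-fold lower number (0.72 log units; beyond the scatter) from compound 3 to compound 4, 21-fold (1.32 log units) apart, beyond the scatter of two such steps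

Within the data shown here, this rests on only one pair of compounds for each core, so it does not show why the direction reverses, and it gives no rule for predicting the step on any further core.

The compounds shown leave open whether the reversal belongs to the methyl alone or would also appear with a chlorine atom, a methoxy group or a longer chain such as ethyl on the same aromatic carbon. They also leave open whether the two cores would part in the same way in cells other than those used here.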